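From Cyano to Carbamoyl: What to Expect of Compound 3

The compounds below may be only part of what the source reports. "The series", "measured", "known", "first", "only" and "open" are said of these compounds alone.

Two closely related molecules have been measured so far, and they share most of their core. In an ADME assay on HEp-2 cells (Homo sapiens) for cytotoxicity (a lower number here means that less compound is tolerated, a higher number that more compound is tolerated), compound 2 `CC(C)CCn1c(Cn2c(=O)n(C(C)C)c3ccccc32)nc2ccc(C#N)cc21` gives 10000 nM, while compound 1 `CC(C)CCn1c(Cn2c(=O)n(C(C)C)c3ccccc32)nc2c(CN)cccc21` gives 7000 nM. These two numbers lie within the usual scatter of repeated measurements, so they cannot be told apart.

The next molecule is compound 3 `CC(C)CCn1c(Cn2c(=O)n(C(C)C)c3ccccc32)nc2ccc(C(N)=O)cc21`, which has not yet been measured. It keeps the structure of compound 2 except for one group, with carbamoyl in place of cyano on an aromatic carbon.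

Among the compounds with values here, no two measured compounds differ in just one place, so no measured step can serve as a direct guide. The expectation therefore stays anchored on compound 2 at 10000 nM, with no shift beyond the scatter anticipated in this assay. The estimate is no change at the digits printed from compound 2 to compound 3 (within the scatter), which is expected to be a step too small to distinguish from repeat-measurement noise. For compound 3, the expected value is 10000 nM, with an estimated range from 4500 nM to 25000 nM.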

Compound 3, half-maximal cytotoxic concentration: 49900 nM
Beside the measured number, compound 3's estimate is 5.0-fold (0.70 log units) below it; measured number above the stated range.
By their numbers in this assay, from the lowest: compounds 1 and 2 (each within the scatter of the next); then compound 3.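

Cyano and carbamoyl are the only difference between these two compounds, so this is the first comparison here that isolates a single change: in this assay, the swap on this aromatic carbon gives a 5.0-fold higher number from compound 2 to compound 3 (0.70 log units; beyond the scatter). The result shows that the group at this position can shift the cytotoxicity read-out by more than the usual scatter, which the earlier pair, differing in more than one place, could not show. Carbamoyl carries a hydrogen-bond donor and cyano does not, but that is only a structural difference between the two groups, and no measurement shown here accounts for the higher number.

The compounds shown leave open whether this step is specific to carbamoyl or would also appear with another group on the same carbon, such as a carboxylic acid, a methyl ester or an amine. They also leave open whether placing carbamoyl on a different carbon of this six-membered aromatic ring would give a step of similar size.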